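This account rests on a few compounds, and the source may have more. Where it says the series, first, only, none or still open, it means among the compounds named here.

Compound 1, `CC(C)[C@@H](NC(=O)c1ccc(F)cc1)C(=O)N1CCC(c2ccc(Cl)cc2)CC1`, gives 118 nM in an assay on THP-1 cells for displacement of a labelled ligand from C-C chemokine receptor type 1 (Homo sapiens); a higher number here means a weaker inhibitor, a lower number a stronger inhibitor.
Compound 2, `Cc1ccc(CCC(=O)N[C@@H](C(=O)N2CCC(c3ccc(Cl)cc3)CC2)C(C)C)cc1`, gives 105 nM in this assay.

Going by the values given here, compound 2 carries the lower of the two numbers measured so far, but its nearest neighbour, compound 1, sits close: the step of a 1.1-fold lower number from compound 1 to compound 2 (0.05 log units; within the scatter) does not rise above the scatter, so the two compounds cannot be told apart on these numbers.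

Compound 3, `CC(C)[C@@H](NC(=O)C1CCCC1)C(=O)N1CCC(c2ccc(Cl)cc2)CC1`, differs from compound 2 at one place: cyclopentyl in place of 2-(4-methylphenyl)ethyl on a carbonyl carbon. Among the compounds with values here, the only measured step that bears on this is a 1.1-fold lower number from compound 1 to compound 2 (0.05 log units; within the scatter), which swapped the group on that same carbonyl carbon and left the number essentially unchanged. That single comparison shows the group on the carbonyl carbon can be varied without a large shift, but it contains no saturated ring, so the new exchange is only loosely anchored. The expected step in this assay is therefore small, a 1.4-fold higher number from compound 2 to compound 3 (0.15 log units; within the scatter), in no clear direction beyond the scatter. Compound 3 is expected to give 150 nM, with a range from 50 nM to 450 nM.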

Compound 3, half-maximal inhibitory concentration: 70 nM
Compound 3: the middle estimate sits 2.1-fold (0.33 log units) above what was measured; the measured number falls inside the stated range.
By their numbers in this assay, from the lowest: compounds 3, 2 and 1 (each within the scatter of the next).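

Swapping the aromatic group for a saturated ring on this carbonyl carbon is the new test in this assay, and it gives a 1.5-fold lower number from compound 2 to compound 3 (0.18 log units; within the scatter) and, against the other aromatic group, a 1.7-fold lower number from compound 1 to compound 3 (0.23 log units; within the scatter) as well. Among these three compounds, then, a benzene-type ring is not needed at this place: cyclopentyl, a five-membered non-aromatic ring with 5 heavy atoms, stands level with 2-(4-methylphenyl)ethyl, which has 9, and with 4-fluorophenyl, so neither the loss of aromaticity nor the smaller size of the group separates these compounds on these numbers. Nothing available here gives a measured reason for this flat result.

The compounds shown leave open whether any group at this place can move the number beyond the scatter at all, since every step so far stays within it. An amine or a carboxylic acid on the group attached to this carbonyl carbon, or a long open carbon chain with no ring, would show whether this place is as forgiving for groups unlike these three.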